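A few compounds are considered here, and "the series" means these few. Any claim that something is new, unique, unknown or untested is made for them only; others in the source may bear on it.

For the measured compounds named here, compound 3, `Nc1scc(CN2CCN(c3cccc(F)c3)CC2)c1C(=O)c1ccc(Cl)cc1`, stands at the top of the three numbers so far in an assay on CHO cells for displacement of a labelled ligand from adenosine receptor A3 (Homo sapiens), read by scintillation counting, with a stated time of 120 min, tested at 10 uM (on this read-out higher numbers stand for more inhibition at the one concentration tested (going by the name of the read-out) and lower numbers for less inhibition), where compound 3 gives 4%. Its two neighbours share the same core and differ from it only in the group on the amine nitrogen in the ring: compound 1, `Nc1scc(CN2CCN(c3ccc(Cl)cc3F)CC2)c1C(=O)c1ccc(Cl)cc1`, gives 1% in this assay, and compound 2, `Nc1scc(CN2CCN(c3cccnc3)CC2)c1C(=O)c1ccc(Cl)cc1`, gives 0%. None of these three stands apart from the others, since the step from compound 1 to compound 3 is a number 3 percentage points higher from compound 1 to compound 3 (within the scatter) and the step from compound 2 to compound 3 is a number 4 percentage points higher from compound 2 to compound 3 (within the scatter).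

Compound 4, `Nc1scc(CN2CCN(c3ccc(F)c(Cl)c3)CC2)c1C(=O)c1ccc(Cl)cc1`, is the next change at the same place: 3-chloro-4-fluorophenyl in place of 3-fluorophenyl on an amine nitrogen in a ring. Going by the values given here, the steps that bear on it are the two exchanges of the aryl group on that ring nitrogen already measured, a number 3 percentage points higher from compound 1 to compound 3 (within the scatter) and a number 4 percentage points higher from compound 2 to compound 3 (within the scatter), and also a number 1 percentage points lower from compound 1 to compound 2 (within the scatter); every one of them lies within the scatter, so another swap of a halogenated phenyl group at this position is expected to give no step beyond the scatter in this assay. The expected step from this estimate is a number 1 percentage points lower from compound 3 to compound 4 (within the scatter). Compound 4 is therefore estimated at 3%, with a range from -5% to 12%.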

Compound 4, a percentage reported as inhibition, at one concentration (the size of the read-out at that concentration, not a potency): 0%
Compound 4: the middle estimate sits 3 percentage points above what was measured, and the stated range covers the measured number.
By their numbers in this assay, from the lowest: compounds 2, 4, 1 and 3 (each within the scatter of the next).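

In this assay the exchange of 3-fluorophenyl for 3-chloro-4-fluorophenyl on the amine nitrogen in the ring gives a number 4 percentage points lower from compound 3 to compound 4 (within the scatter) and so adds a chlorine-bearing group that does not separate from the smaller 3-fluorophenyl. The new group also stays level with the pyridin-3-yl group, with no change at the digits printed from compound 2 to compound 4 (within the scatter) as the step, and with the other phenyl group carrying both chlorine and fluorine, with a number 1 percentage points lower from compound 1 to compound 4 (within the scatter) as the step, so a change of halogen pattern and a change from phenyl to pyridin-3-yl read alike here. All four groups on this nitrogen now lie within the scatter of one another at the one concentration tested, which gives them no order, and no measurement at hand speaks to why this position is so flat.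

The compounds shown all keep an aromatic ring directly on this nitrogen, so it remains open whether a benzyl group, an acetyl group or a longer alkyl chain there would give a reading that stands apart. They also leave open whether any change elsewhere on the shared core, such as replacing the free amine with an amide, would move the number beyond the scatter.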